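The source may hold more compounds than are shown below. What is called first, only, known or untested is meant among the compounds shown, and "the series" means these compounds.

Values in a functional assay on the whole organism for antagonist activity, with Mus musculus as the target, in the maximal electroshock model (a higher number here means that more compound is needed for the effect, a lower number that less compound is needed), for the measured compounds:
compound 1 `COC(=O)NC1=NC(c2cccc(F)c2)CN1` gives 70 mg/kg
compound 2 `COC(=O)NC1=NC(c2cccc(Cl)c2)CN1` gives 48 mg/kg
compound 3 `COC(=O)NC1=NC(c2ccccc2F)CN1C` gives 74 mg/kg

Compounds 1 and 2 share one core; compound 3 carries another, and the difference between the two cores is not broken down here. From compound 1 to compound 2 the change is chloro in place of fluoro on an aromatic carbon, and in this assay it made a 1.5-fold lower number from compound 1 to compound 2 (0.16 log units; within the scatter). Compound 3 stands nearest compound 1 and furthest from compound 2, with both gaps within the scatter, so no order among the three is claimed.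

Compound 4 `COC(=O)NC1=NC(c2ccccc2Cl)CN1C` is not yet measured. It stands to compound 3 as compound 2 stands to compound 1: chloro in place of fluoro on an aromatic carbon. The place is not the same word for word: in compound 2 the entering chloro sits meta to a large group, in compound 4 ortho to a large group, so this counts as the same kind of change, not the same change. The expectation for compound 4 in this assay is a step of a 1.2-fold lower number from compound 3 to compound 4 (0.09 log units; within the scatter), resting on the earlier step of a 1.5-fold lower number from compound 1 to compound 2 (0.16 log units; within the scatter), which lay within the scatter. Compound 4 is therefore estimated at 60 mg/kg, expected between 30 mg/kg and 120 mg/kg.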

Compound 4, dose for half-maximal effect: 28 mg/kg
For compound 4 the middle estimate is 2.1-fold (0.33 log units) above the measured one; the measured number lies below the stated range.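

In this assay, chloro in place of fluoro on an aromatic carbon gives a 2.6-fold lower number from compound 3 to compound 4 (0.42 log units; beyond the scatter), a modest step on the core of compound 3. The size of this step does not separate the two cores: the same change on two cores in this assay, a 1.5-fold lower number (0.16 log units; within the scatter) from compound 1 to compound 2 and a 2.6-fold lower number (0.42 log units; beyond the scatter) from compound 3 to compound 4, 1.8-fold (0.26 log units) apart, within the scatter of two such steps. Among these compounds, nothing here shows the change behaving differently on the two cores, but transfer between them is not established either: only the step on the core of compound 3 lies beyond the scatter, each core supplies a single pair, and the entering chloro sits ortho to a large group in compound 4 but elsewhere in compound 2, so the effects of core and place cannot be told apart.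

Still open, going by these compounds, is how a methoxy, nitrile or trifluoromethyl group on the same aromatic carbon would read in this assay, and whether the step holds with chloro at one and the same place on both cores. The compounds shown also leave open what an amine or a longer chain elsewhere on the core would do.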